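Swapping the Amide for a Methyl Ester

This account rests on a few compounds, and the source may have more. Where it says the series, first, only, none or still open, it means among the compounds named here.

Compound 1, `Nc1sc(-c2ccc(Cl)cc2)c(-c2ccc(Cl)cc2)c1C(=O)N1CCCC1`: 6220 nM
Compound 2, `CC(C)(C)NC(=O)c1c(N)sc(-c2ccc(Cl)cc2)c1-c1ccc(Cl)cc1`: 15100 nM
Compound 3, `CN1CCN(C(=O)c2c(N)sc(-c3ccc(Cl)cc3)c2-c2ccc(Cl)cc2)CC1`: 13100 nM

In a functional assay on PC-3 cells (Homo sapiens) for inhibition, read by sulforhodamine B assay, with a stated time of 72 h (a higher number here means a weaker inhibitor, a lower number a stronger inhibitor), compound 3 stands second highest of the three numbers; compound 2 lies within the scatter of it, while the step of a 2.1-fold higher number from compound 1 to compound 3 (0.32 log units; beyond the scatter) lies beyond it. Compound 4, `COC(=O)c1c(N)sc(-c2ccc(Cl)cc2)c1-c1ccc(Cl)cc1`, differs from compound 3 only at the carbonyl carbon: methoxy in place of 4-methylpiperazin-1-yl on a carbonyl carbon. For the measured compounds named here, no measured step exchanges an amide for an ester, so no direct precedent exists. The steps at the same position, a 2.4-fold higher number from compound 1 to compound 2 (0.39 log units; beyond the scatter) and a 1.2-fold lower number from compound 2 to compound 3 (0.06 log units; within the scatter), show that changing the group on this carbonyl shifted the number modestly or not beyond the scatter. A step of similar size, in no preferred direction, is therefore expected. Compound 4 is estimated at 10000 nM, between 4000 nM and 30000 nM, which means an expected 1.3-fold lower number from compound 3 to compound 4 (0.12 log units; within the scatter).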

Compound 4, half-maximal inhibitory concentration: 2780 nM
Compound 4: the middle estimate sits 3.6-fold (0.56 log units) above what was measured, outside the stated range (below it).
By their numbers in this assay, from the lowest: compound 4; then compound 1; then compounds 3 and 2 (each within the scatter of the next).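

In this assay compound 4, with methoxy on the carbonyl carbon, gives the lowest number of the four, lower than each amide (a 4.7-fold lower number from compound 3 to compound 4 (0.67 log units; beyond the scatter)) (a 5.4-fold lower number from compound 2 to compound 4 (0.73 log units; beyond the scatter)) (a 2.2-fold lower number from compound 1 to compound 4 (0.35 log units; beyond the scatter)). The three amines tried on this carbonyl therefore do not mark the best this position can give, since an ester goes lower than any of them. Nothing shown here explains why the methoxy ester gives the lower number. Going by these compounds, whether an ethyl ester or a free carboxylic acid at this carbonyl would go lower still remains open.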